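Pyrazole chalcones: removing one methoxy, pyridine regioisomers compared

The compounds below may be only part of what the source reports. "The series", "measured", "known", "first", "only" and "open" are said of these compounds alone.

Measured compounds in a functional assay on MCF7 cells (Homo sapiens) for inhibition, read by sulforhodamine B assay, with a stated time of 72 h; on this read-out higher numbers stand for weaker inhibition and lower numbers for stronger inhibition:
- compound 1 `COc1cc(C(=O)/C=C/c2cn(-c3ccccc3)nc2-c2cccnc2)cc(OC)c1OC` gives 14500 nM
- compound 2 `COc1ccc(C(=O)/C=C/c2cn(-c3ccccc3)nc2-c2cccnc2)cc1OC` gives 1700 nM
- compound 3 `COc1ccc(C(=O)/C=C/c2cn(-c3ccccc3)nc2-c2ccncc2)c(OC)c1OC` gives 3300 nM

Compound 1 and compound 2 share a core and differ in one place: hydrogen in place of methoxy on an aromatic carbon. That change gave an 8.5-fold lower number from compound 1 to compound 2 (0.93 log units; beyond the scatter) in this assay.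

Compound 3 carries a different core; how the core of compound 3 differs from that of compound 1 is not broken down here. In this assay compound 3 sits a little under compound 1 and close to compound 2, within the scatter of compound 2.

Compound 4 `COc1ccc(C(=O)/C=C/c2cn(-c3ccccc3)nc2-c2ccncc2)cc1OC` is not yet measured. It arises from compound 3 by the same kind of change as that from compound 1 to compound 2: hydrogen in place of methoxy on an aromatic carbon. The surroundings are not identical: in compound 1 the departing methoxy is meta to a large group and ortho to a methoxy group, whereas in compound 3 it is ortho to a large group, ortho to a methoxy group and meta to a methoxy group. Among the compounds with values here, the expectation therefore leans on the single measured step from compound 1 to compound 2, tempered for the different placement. Compound 4 is expected to give 900 nM in this assay, with a range from 300 nM to 3000 nM. Within the data shown here, this estimate means a step of a 3.7-fold lower number from compound 3 to compound 4 (0.56 log units; beyond the scatter), smaller than the one seen from compound 1 to compound 2, because that step an 8.5-fold lower number from compound 1 to compound 2 (0.93 log units; beyond the scatter) was made at a differently placed methoxy and only one such example exists.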

Compound 4, half-maximal inhibitory concentration: 4300 nM
Compound 4: middle estimate off by 4.8-fold (0.68 log units), on the low side, and the stated range ends below it.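

In this assay, hydrogen in place of methoxy on an aromatic carbon does not carry over from one core to the other, and the two steps differ: the same change on two cores in this assay, an 8.5-fold lower number (0.93 log units; beyond the scatter) from compound 1 to compound 2 and a 1.3-fold higher number (0.11 log units; within the scatter) from compound 3 to compound 4, 11-fold (1.05 log units) apart, beyond the scatter of two such steps. The new step, a 1.3-fold higher number from compound 3 to compound 4 (0.11 log units; within the scatter), lies within the scatter, so on this core the change gives no readable shift, whereas the earlier step on the core of compound 1 was clear. Within the data shown here, with only one step on each core, these data do not show whether the gap follows the placement of the departing methoxy or some other difference between the cores, and the separate change of pyridin-4-yl in place of pyridin-3-yl, a 2.5-fold higher number from compound 2 to compound 4 (0.40 log units; beyond the scatter), is a modest step seen on a single pair, so it gives no general rule for that position.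

The compounds shown leave open how the read-out responds when a hydroxy group, a fluorine atom or an amine takes the place of the departing methoxy on the same aromatic carbon. They also leave open whether a pyridin-2-yl group would follow compound 2 or compound 4, and whether the step seen between compound 1 and compound 2 recurs on any further core.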